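Swapping the Pyrrolidine Side Chain for Trifluoromethylsulfonyl

A few compounds are considered here, and "the series" means these few. Any claim that something is new, unique, unknown or untested is made for them only; others in the source may bear on it.

Compound 1 `Cc1cc(C)cc(S(=O)(=O)c2c(C(=O)N[C@@H]3CCN(Cc4ccccc4C#N)C3)[nH]c3ccc(Cl)cc23)c1`: >= 186000 nM
Compound 2 `Cc1cc(C)cc(S(=O)(=O)c2c(C(=O)N[C@H]3CCN(Cc4cccnc4)C3)[nH]c3ccc(Cl)cc23)c1`: 22800 nM

In an ADME assay on MT4 cells (Homo sapiens) for cytotoxicity, read by MTT assay, with a stated time of 5 days (a higher number here means that more compound is tolerated, a lower number that less compound is tolerated), compound 1 reaches only a limit, >= 186000 nM. Compound 2 gives 22800 nM in this assay, the single plain number shown; the other entry is the limit of >= 186000 nM in this assay, at which 1 of the 2 values shown sits. Compound 3 `Cc1cc(C)cc(S(=O)(=O)c2c(C(=O)NS(=O)(=O)C(F)(F)F)[nH]c3ccc(Cl)cc23)c1` differs from compound 2 by (trifluoromethyl)sulfonyl in place of 1-((pyridin-3-yl)methyl)pyrrolidin-3-yl on an amide-type nitrogen. Going by the values given here, no step between two measured compounds is available to calibrate this change. Compound 3 is expected to be tolerated better than compound 2, with an expected step of a 3.9-fold higher number from compound 2 to compound 3 (0.60 log units; beyond the scatter). Compound 3 is estimated at 90000 nM, between 30000 nM and 200000 nM.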

Compound 3, half-maximal cytotoxic concentration: 141000 nM
Compound 3: the middle estimate sits 1.6-fold (0.19 log units) below what was measured, and the stated range covers the measured number.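

On the amide-type nitrogen, (trifluoromethyl)sulfonyl in place of 1-((pyridin-3-yl)methyl)pyrrolidin-3-yl gives a 6.2-fold higher number from compound 2 to compound 3 (0.79 log units; beyond the scatter) in this assay. Going by these compounds alone, this is the first measured step at this position, and it shows that more compound is tolerated when the side chain with its two rings gives way to a group with no ring. Compound 1 remains a limit and not a number, so the standing of compound 3 against it cannot be read: the limit of >= 186000 nM in this assay, at which 1 of the 3 values shown sits.

The compounds shown leave open which part of the change carries the step. A methylsulfonyl group or a bare pyrrolidin-3-yl on the same nitrogen could separate the contributions of the entering and leaving groups.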